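Swapping a hydroxyalkyl side chain for an aminocyclohexyl ring

A few compounds are considered here, and "the series" means these few. Any claim that something is new, unique, unknown or untested is made for them only; others in the source may bear on it.

Measured so far, all in a functional assay on G-361 cells (Homo sapiens) for cytotoxicity, read by fluorescence, with a stated time of 72 h; a higher number here means a weaker inhibitor, a lower number a stronger inhibitor:
- compound 1, `CC(C)c1n[nH]c2c(NCc3ccc(-c4ccccn4)cc3)nc(S(C)(=O)=O)nc12`, compound 1 gives 793 nM
- compound 2, `CC(C)c1n[nH]c2c(NCc3ccc(-c4ccccn4)cc3)nc(NCC(C)(C)O)nc12`, compound 2 gives 48 nM
- compound 3, `CC(C)c1n[nH]c2c(NCc3ccc(-c4ccccn4)cc3)nc(N3CCNCC3)nc12`, compound 3 gives 64 nM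

Compound 2 has the lowest number of the three. The step of a 17-fold lower number from compound 1 to compound 2 (1.22 log units; beyond the scatter) and the step of a 12-fold lower number from compound 1 to compound 3 (1.09 log units; beyond the scatter) are both large, while the step of a 1.3-fold higher number from compound 2 to compound 3 (0.12 log units; within the scatter) stays within the scatter. Compound 4, `CC(C)c1n[nH]c2c(NCc3ccc(-c4ccccn4)cc3)nc(N[C@H]3CC[C@H](N)CC3)nc12`, is not yet measured. It differs from compound 2 by 4-aminocyclohexyl in place of 2-hydroxy-2-methylpropyl on a nitrogen on an aromatic ring. Among the measured compounds shown here, the only step that bears on this change is the one from compound 2 to compound 3, where a ring bearing a nitrogen replaced the hydroxyalkyl chain without a change beyond the scatter. The number for compound 4 is therefore expected to stay close, with the step of a 1.1-fold higher number from compound 2 to compound 4 (0.06 log units; within the scatter) estimated to lie within the scatter. Compound 4 is expected at about 55 nM, in a range from 20 nM to 150 nM.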

Compound 4, half-maximal inhibitory concentration: 745 nM
Beside the measured number, compound 4's estimate is 14-fold (1.13 log units) below it; measured number above the stated range.
By their numbers in this assay, from the lowest: compounds 2 and 3 (each within the scatter of the next); then compounds 4 and 1 (each within the scatter of the next).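

In this assay, among the compounds shown here, this position proves far less tolerant than the earlier compounds suggested: (4-aminocyclohexyl)amino gives a 16-fold higher number from compound 2 to compound 4 (1.19 log units; beyond the scatter) and a 12-fold higher number from compound 3 to compound 4 (1.07 log units; beyond the scatter), so the match between compound 2 and compound 3 does not extend to this ring. The gain seen over methylsulfonyl also disappears, with a 1.1-fold lower number from compound 1 to compound 4 (0.03 log units; within the scatter). No measurement here explains this loss.

Still open, going by these compounds, is whether the loss follows from the ring, its amine or its stereochemistry. A plain cyclohexyl group, a 4-hydroxycyclohexyl group or the other stereoisomer of 4-aminocyclohexyl would help separate these.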